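Methyl for iodo on the aminochalcone series

The source may report more compounds than this note shows. Statements on the series, on what has been measured and on what is new or still open speak of the compounds shown alone.

Compound 1 `C=C(Br)C(=O)Nc1ccc(/C=C/C(=O)c2ccc(I)cc2)cc1`, compound 2 `C=C(Br)C(=O)Nc1ccc(/C=C/C(=O)c2ccc(C)cc2)cc1` and compound 3 `Nc1ccc(/C=C/C(=O)c2ccc(I)cc2)cc1` have been run in a functional assay on MOLT-4 cells (Homo sapiens) for antiproliferative activity, with a stated time of 48 h; a lower number here means a stronger inhibitor, a higher number a weaker inhibitor. Compound 1 gives 2800 nM, compound 2 gives 1700 nM and compound 3 gives 7500 nM. The change from compound 1 to compound 2, (methyl in place of iodo on an aromatic carbon), produced a 1.6-fold lower number from compound 1 to compound 2 (0.22 log units; within the scatter). The cores of compound 1 and compound 3 differ by hydrogen in place of (1-bromoethenyl)carbonyl on a nitrogen on an aromatic ring, and that difference produced a 2.7-fold higher number from compound 1 to compound 3 (0.43 log units; beyond the scatter). Compound 4 `Cc1ccc(C(=O)/C=C/c2ccc(N)cc2)cc1` carries the same change as compound 2, now made on the core of compound 3: methyl in place of iodo on an aromatic carbon. The earlier step from this change lay within the scatter. On that basis a similarly small step is expected, estimated as a 1.5-fold lower number from compound 3 to compound 4 (0.18 log units; within the scatter) in this assay. Compound 4 is accordingly expected near 5000 nM, within 2500 nM to 10000 nM.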

Compound 4, half-maximal inhibitory concentration: 12000 nM
The estimate for compound 4 lay 2.4-fold (0.38 log units) below the measured number, outside the stated range (above it).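

In this assay methyl in place of iodo gives a 1.6-fold higher number from compound 3 to compound 4 (0.20 log units; within the scatter), and the two steps for this change on the two cores cannot be told apart: the same change on two cores in this assay, a 1.6-fold lower number (0.22 log units; within the scatter) from compound 1 to compound 2 and a 1.6-fold higher number (0.20 log units; within the scatter) from compound 3 to compound 4, 2.6-fold (0.42 log units) apart, within the scatter of two such steps.
Hydrogen in place of (1-bromoethenyl)carbonyl on the nitrogen gives a 7.1-fold higher number from compound 2 to compound 4 (0.85 log units; beyond the scatter), a step in the same direction as on the other core and again not distinguishable from it: the same change on two cores in this assay, a 2.7-fold higher number (0.43 log units; beyond the scatter) from compound 1 to compound 3 and a 7.1-fold higher number (0.85 log units; beyond the scatter) from compound 2 to compound 4, 2.6-fold (0.42 log units) apart, within the scatter of two such steps.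
Across these two cores, then, both changes carry over within the scatter, but this does not show that their sizes are equal or that they would hold on any further core.

Still open, from the compounds shown here alone, is whether a chloro or a methoxy in place of iodo would stay within the scatter. Also open, going by these compounds, is whether an acetyl on the nitrogen would give a step like that of (1-bromoethenyl)carbonyl.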